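Methylating the Linking Nitrogen of a Benzothiophene Analogue

The source may report more compounds than this note shows. Statements on the series, on what has been measured and on what is new or still open speak of the compounds shown alone.

Compound 1, `CCOC(=O)c1cnc(NN2C(=O)C=C(C)C2=O)nc1-c1cccs1`: 140 nM
Compound 2, `CCOC(=O)c1cnc(NN2C(=O)C=C(C)C2=O)nc1-c1cc2ccccc2s1`: 800 nM

Among the compounds with values here, in a functional assay on Jurkat cells (Homo sapiens) for inhibition (a lower number here means a stronger inhibitor, a higher number a weaker inhibitor), compound 2 gives 800 nM, the higher of the two numbers measured; the only step known so far is a 5.7-fold higher number from compound 1 to compound 2 (0.76 log units; beyond the scatter).

Compound 3, `CCOC(=O)c1cnc(N(C)N2C(=O)C=C(C)C2=O)nc1-c1cc2ccccc2s1`, carries methyl in place of hydrogen on a nitrogen on an aromatic ring. That measured step concerns the ring at the other end of the shared core and says nothing about this nitrogen, so neither size nor direction of the change can be read from the data. Compound 3 is therefore expected, with a deliberately broad range, to give 1500 nM (from 300 nM to 8000 nM), an expected step of a 1.9-fold higher number from compound 2 to compound 3 (0.27 log units; within the scatter).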

Compound 3, half-maximal inhibitory concentration: 130 nM
The estimate for compound 3 lay 12-fold (1.06 log units) above the measured number; measured number outside the range, below it.
By their numbers in this assay, from the lowest: compounds 3 and 1 (each within the scatter of the next); then compound 2.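

In this assay, the linking nitrogen proves to be a sensitive position: methyl in place of hydrogen there gives a 6.2-fold lower number from compound 2 to compound 3 (0.79 log units; beyond the scatter). A hydrogen on this nitrogen is therefore not needed for activity in the compound carrying 1-benzothiophen-2-yl. Nothing measured here explains why the number falls.

As far as these compounds go, it remains open whether the same methyl would change the number similarly in compound 1, which carries thiophen-2-yl. From the compounds shown here alone, it is also open whether ethyl, a longer chain or an acetyl group on this nitrogen would act as methyl does.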